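Phenyl to 1,3-benzoxazol-2-yl: working notes on compound 3

This account rests on a few compounds, and the source may have more. Where it says the series, first, only, none or still open, it means among the compounds named here.

In an ADME assay on HepG2 cells (Homo sapiens) for cytotoxicity, with a stated time of 72 h (a lower number here means that less compound is needed, a higher number that more compound is needed for the effect), compound 2 (`O=C(Nc1cccc(-c2ccccc2)c1)c1cc([N+](=O)[O-])ccc1Cl`) stands at > 27000 nM as a limit only. Compound 1 (`O=C(Nc1ccc(F)c(-c2nc3ccccc3o2)c1)c1cc([N+](=O)[O-])ccc1Cl`) stands at > 25000 nM and this too is a limit. Compound 3 (`O=C(Nc1cccc(-c2nc3ccccc3o2)c1)c1cc([N+](=O)[O-])ccc1Cl`) carries 1,3-benzoxazol-2-yl in place of phenyl on an aromatic carbon. Among the measured compounds shown here, no measured step in this assay sizes this change, so none beyond the scatter is expected, in either direction. The expected step is a step that the limit leaves unreadable from compound 2 to compound 3 in this estimate. The expected value for compound 3 is 28000 nM (estimated range 13000 nM to 55000 nM).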

Compound 3, half-maximal effective concentration: > 25000 nM
Compound 3 ended at the assay's limit; the forecaster's own chance of this, stated with the estimate: 80%; the middle value lies beyond the limit too.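

In this assay, compound 1, compound 2 and compound 3 all stand as limits, so no step can be read from compound 2 to compound 3 or from compound 1 to compound 3. The compounds shown leave open where any of the three truly lies.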